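Series notes on a change at one ring carbon

The source may hold more compounds than are shown below. What is called first, only, known or untested is meant among the compounds shown, and "the series" means these compounds.

Two members of the series have been measured in an assay on CHO cells for displacement of a labelled ligand from adenosine receptor A1 (Homo sapiens), read by scintillation counting, tested at 10 uM; on this read-out lower numbers stand for less inhibition and higher numbers for more inhibition at the one concentration tested (going by the name of the read-out). Compound 1 `Nc1sc(-c2ccccc2)c(-c2ccccc2)c1C(=O)c1ccc(Cl)cc1` gives 1% in this assay. Compound 2 `CC(C)(C)Cc1c(-c2ccc(F)cc2F)sc(N)c1C(=O)c1ccc(Cl)cc1` gives 1% in this assay, level with compound 1 at the digits shown and within the usual scatter of that pair. Within the data shown here, no step between the two measured compounds is available, so the pair shows only that both sit at the floor of the read-out.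

Compound 3 `COc1ccccc1-c1sc(N)c(C(=O)c2ccc(Cl)cc2)c1CC(C)(C)C` has not yet been measured in this assay. It differs from compound 2 in one place: 2-methoxyphenyl in place of 2,4-difluorophenyl on an aromatic carbon. With compound 2 at 1% and compound 1 at the same level, nothing in the measured data points in either direction for this change. In this assay the expected step is a number 2 percentage points higher from compound 2 to compound 3 (within the scatter), no larger than the scatter in either direction. For compound 3 the expected value in this assay is 3%, with a range from -5% to 15%.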

Compound 3, a percentage reported as inhibition, at one concentration (the size of the read-out at that concentration, not a potency): 1%
Compound 3: middle estimate off by 2 percentage points, on the high side; the range from low to high includes it.
By their numbers in this assay, from the lowest: compounds 1, 2 and 3 (each within the scatter of the next).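

Among these compounds, at the aromatic carbon next to the ring sulfur, 2-methoxyphenyl in place of 2,4-difluorophenyl gives no change at the digits printed from compound 2 to compound 3 (within the scatter) in this assay, the first step that can be read at this position. The exchange removes two fluorine atoms and brings in one oxygen and one hydrogen-bond acceptor, and the value stays level, so these differences leave no mark on this read-out at the one concentration tested. Nothing at hand accounts for this result.

With all three compounds at the same low level, a flat step cannot separate a position that has no bearing on the read-out from one whose effect is hidden at that level. As far as these compounds go, whether a carboxylic acid or an amine at this carbon would lift the value in this assay remains open.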